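This account rests on a few compounds, and the source may have more. Where it says the series, first, only, none or still open, it means among the compounds named here.

Measured so far:
compound 1 `CN(C[C@H]1Cc2c(cccc2N2CCN(C3CC3)CC2)CN1)[C@H]1CCCc2cccnc21` — 265 nm/s
compound 2 `c1cnc2c(c1)CCC[C@@H]2N(CC1CC1)C[C@H]1Cc2c(cccc2N2CCNCC2)CN1` — 87 nm/s
compound 3 `CN(C[C@@H]1Cc2c(cccc2N2CCNCC2)CN1)[C@H]1CCCc2cccnc21` — 4 nm/s

In an ADME assay for permeability, using PAMPA, at pH 7.4 (on this read-out higher numbers stand for higher permeability and lower numbers for lower permeability), compound 2 gives 87 nm/s, the second highest of the three numbers. Compound 1 gives 265 nm/s, the higher of the two by a gap beyond the scatter; compound 3 gives 4 nm/s, the far lower one, again by a gap beyond the scatter.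

Compound 4 `CCN(C[C@H]1Cc2c(cccc2N2CCNCC2)CN1)[C@H]1CCCc2cccnc21` is the next one to be measured in this assay. It differs from compound 2 in one place: methyl in place of cyclopropyl on a saturated chain carbon bound to an amine nitrogen. No pair of measured compounds differs in exactly this way, so the size of this step cannot be read off a shown step. What the numbers show is that compound 3, which carries methyl on that chain carbon but differs from compound 4 at another centre as well, gives the lowest value of the three, while compound 2 with cyclopropylmethyl gives a clearly higher one. Compound 4, with ethyl, is expected to land between these two, with the step from compound 2 to compound 4 estimated as a 3.5-fold lower number from compound 2 to compound 4 (0.54 log units; beyond the scatter), a drop beyond the scatter. The value expected for compound 4 in this assay is 25 nm/s, with a range from 8 nm/s to 70 nm/s.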

Compound 4, apparent permeability: 75 nm/s
Compound 4: middle estimate off by 3.0-fold (0.48 log units), on the low side; measured number outside the range, above it.
By their numbers in this assay, from the lowest: compound 3; then compounds 4 and 2 (each within the scatter of the next); then compound 1.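

In this assay, the first step readable at this place, methyl in place of cyclopropyl on a saturated chain carbon bound to an amine nitrogen, comes to a 1.2-fold lower number from compound 2 to compound 4 (0.06 log units; within the scatter) and leaves the two compounds indistinguishable on this read-out. Read as cyclopropylmethyl to ethyl, the change removes the three-membered ring of carbon only, with no difference in hydrogen-bond donors, hydrogen-bond acceptors or net charge, and this single pair gives no sign that the ring matters at this position in this assay. No measurement of any other kind bears on this result, so the step stands as an observation without a stated cause.

Still open, from the compounds shown here alone, is how this position responds to groups unlike the two compared here, such as a longer chain, an amine or a carboxylic acid on the same chain carbon. Also open, going by these compounds, is whether the step holds on other versions of the series, as compound 1 and compound 3 each differ in more than one place from both compound 2 and compound 4 and so give no reading of this change.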